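This account rests on a few compounds, and the source may have more. Where it says the series, first, only, none or still open, it means among the compounds named here.

Compound 2, `CCCCCCCCCCCCCCNC(=O)[C@@H](NC(=O)c1cc2ccccc2o1)[C@@H](C)O`, was tested in a functional assay on MCF7 cells (Homo sapiens) for cytotoxicity, read by MTT assay, with a stated time of 48 h (on this read-out lower numbers stand for stronger inhibition and higher numbers for weaker inhibition), and gave 23400 nM. Among the three compounds measured, it stands second highest; its closest neighbour is compound 3, `CCCCCCCCCCCCCCNC(=O)[C@@H](NC(=O)c1nccc2ccccc12)[C@@H](C)O`, which in this assay gave 22800 nM, and the furthest is compound 1, `CCCCCCCCNC(=O)[C@@H](NC(=O)c1cc2ccccc2o1)[C@@H](C)O`, which gave 47200 nM. Both gaps are within the scatter, so the three numbers cannot be told apart in order.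

Compound 4, `CCCCCCCCCCCCCCNC(=O)[C@@H](NS(=O)(=O)c1ccc(C)cc1)[C@@H](C)O`, is not yet measured. It differs from compound 2 in one place: (4-methylphenyl)sulfonyl in place of (1-benzofuran-2-yl)carbonyl on an amine nitrogen. Within the data shown here, two measured steps bear on this. The step from compound 2 to compound 3, a 1.0-fold lower number from compound 2 to compound 3 (0.01 log units; within the scatter), exchanged one aromatic acyl group for another at the same nitrogen and moved the number not at all beyond the scatter. The step from compound 1 to compound 2, a 2.0-fold lower number from compound 1 to compound 2 (0.30 log units; within the scatter), lengthened the chain and also stayed within the scatter. Among the measured compounds shown here, no measured step replaces a carbonyl with a sulfonyl at this nitrogen, so that part of the change is untested. On the evidence available, the expectation for compound 4 is a step of a 1.3-fold higher number from compound 2 to compound 4 (0.11 log units; within the scatter), that is, no shift beyond the scatter. Compound 4 is therefore estimated at 30000 nM, within a range from 10000 nM to 90000 nM.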

Compound 4, half-maximal inhibitory concentration: 12900 nM
For compound 4 the middle estimate is 2.3-fold (0.37 log units) above the measured one; the range from low to high includes it.
By their numbers in this assay, from the lowest: compounds 4, 3, 2 and 1 (each within the scatter of the next, the first and the last beyond it).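

Among these compounds, compound 4 is the first case in which the group on this amine nitrogen is attached through a sulfonyl rather than a carbonyl, and in this assay the exchange gives a 1.8-fold lower number from compound 2 to compound 4 (0.26 log units; within the scatter). The change also replaces the two aromatic rings of (1-benzofuran-2-yl)carbonyl with the single six-membered aromatic ring of (4-methylphenyl)sulfonyl, so neither the linking group nor the ring count, changed together in this one step, moves the number beyond the scatter, though the step cannot show what each does alone. Nothing available accounts for the size of this step or tells whether the two parts of the change act in the same direction.

Going by these compounds, what remains open is whether the nitrogen needs an aromatic acyl or sulfonyl group at all, since a plain amine at this place, or a small aliphatic group such as acetyl, would test that directly. On these data alone, it is also open whether a carboxylic acid or an amine in place of the methyl of the (4-methylphenyl)sulfonyl group, or a longer chain on the amide nitrogen, would move the number beyond the scatter.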